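This account rests on a few compounds, and the source may have more. Where it says the series, first, only, none or still open, it means among the compounds named here.

Of the compounds shown here, two have numbers so far. Compound 1 `Cc1cc(Nc2nc(Cl)nc3[nH]ncc23)n[nH]1` gives 5940 nM in an assay on isolated protein for inhibition of serine/threonine-protein kinase PAK 4 (Homo sapiens), read by HTRF, with a stated time of 60 min (a higher number here means a weaker inhibitor, a lower number a stronger inhibitor), and compound 2 `Cc1cc(Nc2nc(NCc3cccc(F)c3)nc3[nH]ncc23)n[nH]1` gives 458 nM in this assay, so compound 2 holds the lowest of the two numbers, with compound 1 well above it. Compound 3 `Cc1cc(Nc2nc(NCc3ccc(F)cc3F)nc3[nH]ncc23)n[nH]1` has not yet been measured. It differs from compound 2 by 2,4-difluorophenyl in place of 3-fluorophenyl on a saturated chain carbon bound to a nitrogen on an aromatic ring. For the measured compounds named here, no measured pair shows a change of this kind, so no step size can be read from the data; the step from compound 2 to compound 3 is expected to be small, probably none beyond the scatter. For compound 3 the estimate in this assay is 350 nM, with a range from 120 nM to 1000 nM, which means an expected step of a 1.3-fold lower number from compound 2 to compound 3 (0.12 log units; within the scatter).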

Compound 3, half-maximal inhibitory concentration: 96.1 nM
Beside the measured number, compound 3's estimate is 3.6-fold (0.56 log units) above it; the whole stated range lies above it.
By their numbers in this assay, from the lowest: compound 3; then compound 2; then compound 1.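

In this assay, 2,4-difluorophenyl in place of 3-fluorophenyl brings a 4.8-fold lower number from compound 2 to compound 3 (0.68 log units; beyond the scatter). This first measured step at this place shows that the number responds to the fluorine pattern on the phenyl ring, even though the group grows only from 7 to 8 heavy atoms and its hydrogen-bond donors and acceptors stay at 0. No measurement at hand explains the drop. From the compounds shown here alone, what remains open is how far each fluorine accounts for the step, and whether plain phenyl, a pyridine ring or a longer chain would fit this place as well.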